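A few compounds are considered here, and "the series" means these few. Any claim that something is new, unique, unknown or untested is made for them only; others in the source may bear on it.

Working notes on the chromanone series.

The three measured compounds share one core and differ at two places. Compound 1 `COc1cc2c(cc1CC=C(C)C)/C(=N/NC(N)=O)C[C@@H](c1ccc(O)cc1)O2` carries the ureido on a double-bonded nitrogen; in a functional assay on PC-3 cells (Homo sapiens) for inhibition, read by sulforhodamine B assay, with a stated time of 48 h (a higher number here means a weaker inhibitor, a lower number a stronger inhibitor), compound 1 gives 27700 nM. Compound 2 `COc1cc2c(cc1CC=C(C)C)/C(=N/O)C[C@@H](c1ccc(O)cc1)O2` has hydroxy in place of ureido on that nitrogen; in this assay compound 2 gives 31600 nM, and the step of a 1.1-fold higher number from compound 1 to compound 2 (0.06 log units; within the scatter). Compound 3 `COc1cc2c(cc1CCC(C)C)C(=O)C[C@@H](c1ccc(O)cc1)O2` keeps a ketone and carries isobutyl on a saturated chain carbon bound to an aromatic carbon; in this assay compound 3 gives 36300 nM. Its number sits with those of compounds 1 and 2, the gaps to both inside the scatter, so the three values read as one level.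

Compound 4 `COc1cc2c(cc1CC1OC1(C)C)C(=O)C[C@@H](c1ccc(O)cc1)O2` differs from compound 3 by 3,3-dimethyloxiran-2-yl in place of isobutyl on a saturated chain carbon bound to an aromatic carbon. Within the data shown here, no measured step touches this side chain, and the only step on record, from ureido to hydroxy, gave no movement beyond the scatter. The expectation for compound 4 is therefore a step of a 1.0-fold lower number from compound 3 to compound 4 (0.02 log units; within the scatter), no larger than the scatter. Compound 4 is estimated at 35000 nM, within 15000 nM to 80000 nM.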

Compound 4, half-maximal inhibitory concentration: 27400 nM
The estimate for compound 4 lay 1.3-fold (0.11 log units) above the measured number; the range from low to high includes it.
By their numbers in this assay, from the lowest: compounds 4, 1, 2 and 3 (each within the scatter of the next).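

In this assay, among these compounds, this is the first step read at the side chain on a saturated chain carbon bound to an aromatic carbon: 3,3-dimethyloxiran-2-yl in place of isobutyl gives a 1.3-fold lower number from compound 3 to compound 4 (0.12 log units; within the scatter), so this change does not separate the two compounds. A three-membered non-aromatic ring with 1 hetero atom and 1 hydrogen-bond acceptor can thus enter at this place with the number staying at the level of compound 3. No supporting data bear on why the number stays at that level.

As far as these compounds go, whether any group at this place can move the number beyond the scatter remains open, for instance an amine, a carboxylic acid or a longer chain. Also open, from the compounds shown here alone, is whether the flat reading seen here would hold with the ketone of compounds 3 and 4 replaced.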